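A few compounds are considered here, and "the series" means these few. Any claim that something is new, unique, unknown or untested is made for them only; others in the source may bear on it.

Measured so far in an assay on cell membranes for displacement of a labelled ligand from proteinase-activated receptor 1 (Homo sapiens), read by scintillation counting, with a stated time of 60 min; on this read-out higher numbers stand for weaker inhibition and lower numbers for stronger inhibition:
Compound 1, `CS(=O)(=O)OC1C[C@@H]2CCCC[C@@H]2[C@H]1/C=C/c1ccc(-c2cccc(F)c2)cn1`, gives 6.4 nM.
Compound 2, `CCOC(=O)NC1C[C@@H]2CCCC[C@@H]2[C@H]1/C=C/c1ccc(-c2cccc(F)c2)cn1`, gives 2000 nM.

Among these two numbers compound 2 stands highest in this assay; its only neighbour is compound 1, and the step of a 310-fold higher number from compound 1 to compound 2 (2.49 log units; beyond the scatter) separates them, far beyond the scatter. Compound 3, `CN(C1C[C@@H]2CCCC[C@@H]2[C@H]1/C=C/c1ccc(-c2cccc(F)c2)cn1)S(C)(=O)=O`, has not been measured. It differs from compound 2 in one place: methyl(methylsulfonyl)amino in place of (ethoxycarbonyl)amino on a saturated ring carbon. Within the data shown here, the single measured step that bears on this change is a 310-fold higher number from compound 1 to compound 2 (2.49 log units; beyond the scatter), in which a group carrying a methylsulfonyl unit was exchanged for the carbamate and the number rose sharply. Compound 3 brings a methylsulfonyl unit back, now attached through nitrogen rather than through oxygen and accompanied by a methyl on that nitrogen, so a move back part of the way toward the number of compound 1 is expected, although nothing measured shows whether the whole distance will be recovered. For compound 3 the expected step is a 20-fold lower number from compound 2 to compound 3 (1.30 log units; beyond the scatter), downward. The estimate for compound 3 in this assay is 100 nM, with a range from 15 nM to 700 nM.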

Compound 3, half-maximal inhibitory concentration: 1.3 nM
Compound 3: the middle estimate sits 77-fold (1.89 log units) above what was measured; the whole stated range lies above it.
By their numbers in this assay, from the lowest: compound 3; then compound 1; then compound 2.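

In this assay, putting methyl(methylsulfonyl)amino in place of (ethoxycarbonyl)amino on this saturated ring carbon gives a 1500-fold lower number from compound 2 to compound 3 (3.19 log units; beyond the scatter), so the high number of compound 2 does not mean that this position accepts only the (methylsulfonyl)oxy group of compound 1. Exchanging that group for methyl(methylsulfonyl)amino gives a 4.9-fold lower number from compound 1 to compound 3 (0.69 log units; beyond the scatter), which shows that the oxygen linking the methylsulfonyl unit to the ring can give way to a methyl-bearing nitrogen with no loss of inhibition, and in fact with a modest gain. Among these three compounds, the two carrying a methylsulfonyl unit have the low numbers and the carbamate has the high one, but no measurement here explains this difference.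

The change from compound 2 to compound 3 swaps the carbamate for a methylsulfonyl unit and also adds a methyl on the nitrogen, so the compounds shown cannot separate these two parts of the change; (methylsulfonyl)amino and methyl(ethoxycarbonyl)amino at this position would pull them apart. As far as these compounds go, how much room the position offers also remains open, and a longer chain on the sulfur, such as ethylsulfonyl in place of methylsulfonyl, would test that.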